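The source may hold more compounds than are shown below. What is called first, only, known or untested is meant among the compounds shown, and "the series" means these compounds.

Working notes on the series. The shared core is that of compound 1 `O=C1NCCN1c1ccc(S(=O)(=O)Nc2cccc(Br)c2)cc1`, which in a functional assay on HT-29 cells (Homo sapiens) for antiproliferative activity, read by sulforhodamine B assay, with a stated time of 48 h (a lower number here means a stronger inhibitor, a higher number a weaker inhibitor), gives 77 nM. Compound 2 `O=C1NCCN1c1ccc(S(=O)(=O)Nc2ccc(OC(F)F)cc2)cc1` gives 650 nM. Compound 3 `CCCCCCOc1ccc(NS(=O)(=O)c2ccc(N3CCNC3=O)cc2)cc1` reaches only the limit of the assay, > 1000 nM, so for compound 3 a limit and not a number is known. Among the measured compounds shown here, the one measured step that leads to compound 3, an at least 1.5-fold higher number from compound 2 to compound 3 (0.18 log units; that floor lies within the scatter), is truncated by that same limit (the limit of > 1000 nM in this assay, at which 1 of the 3 values shown sits), so its true size is open. Compound 4 `O=C1NCCN1c1ccc(S(=O)(=O)Nc2ccccc2)cc1` differs from compound 3 by hydrogen in place of hexyloxy on an aromatic carbon. For the measured compounds named here, no measured step strips a group from that ring entirely, so the expectation leans on compound 2, which in this assay gives 650 nM, and on compound 1, which gives 77 nM. The step from compound 3 is expected to run toward a lower number, an at least 2.0-fold lower number from compound 3 to compound 4 (0.30 log units; that floor lies within the scatter), with the limit of compound 3 leaving that direction open. Compound 4 is therefore estimated at 500 nM, within 150 nM to 1500 nM.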

Compound 4, half-maximal inhibitory concentration: 280 nM
For compound 4 the middle estimate is 1.8-fold (0.25 log units) above the measured one; the measured number falls inside the stated range.
By their numbers in this assay, from the lowest: compound 1; then compound 4; then compound 2. At a limit, above all of these: compound 3.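

In this assay, compound 4 gives the series a reference with hydrogen on this ring, and removing a group does not shift the number one way: hydrogen in place of difluoromethoxy gives a 2.3-fold lower number from compound 2 to compound 4 (0.37 log units; beyond the scatter), while hydrogen in place of bromo gives a 3.6-fold higher number from compound 1 to compound 4 (0.56 log units; beyond the scatter). Hydrogen in place of hexyloxy gives an at least 3.5-fold lower number from compound 3 to compound 4 (0.55 log units; beyond the scatter), so among the groups shown only bromo stands on the lower side of hydrogen. Compound 3 stands at a limit, so that step gives only a floor: the limit of > 1000 nM in this assay, at which 1 of the 4 values shown sits.

The compounds shown leave open whether an amine, a carboxylic acid or a shorter chain such as methoxy would fall on the side of bromo or of difluoromethoxy. As far as these compounds go, the true size of the step from hexyloxy to hydrogen also remains open.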